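A few compounds are considered here, and "the series" means these few. Any claim that something is new, unique, unknown or untested is made for them only; others in the source may bear on it.

Measured so far in a physicochemical assay for solubility, at pH 5.0; a higher number here means a more soluble compound, a lower number a less soluble compound:
Compound 1 `C[C@@H]1CN(Cc2ccnc3ccccc23)CCN1S(=O)(=O)c1ccc(C(C)(C)C)cc1`: 1 ug/mL
Compound 2 `C[C@@H]1CN(c2ccc([N+](=O)[O-])cc2)CCN1S(=O)(=O)c1ccc(C(C)(C)C)cc1`: 1.8 ug/mL

Compound 2, at 1.8 ug/mL, lies within the usual scatter of compound 1, so these two measurements cannot be told apart. The next compound to be tested is compound 3 `CC(c1ccncc1)N1CCN(S(=O)(=O)c2ccc(C(C)(C)C)cc2)[C@H](C)C1`, which has not yet been measured. Compared with compound 2, it differs in a single place: 1-(pyridin-4-yl)ethyl in place of 4-nitrophenyl on an amine nitrogen in a ring. In plain words, 1-(pyridin-4-yl)ethyl stands in place of 4-nitrophenyl on an amine nitrogen in a ring, so an aromatic ring of carbon only gives way to one with a hetero atom.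

Among the measured compounds shown here, no two measured compounds differ in just one place, so there is no measured step to use as a guide. The expectation rests on the structural change alone and is therefore uncertain. A clear rise in this assay, beyond the scatter, is expected. The estimated change is a 17-fold higher number from compound 2 to compound 3 (1.22 log units; beyond the scatter). Compound 3 is expected to give 30 ug/mL, with an estimated range from 4 ug/mL to 150 ug/mL.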

Compound 3, solubility: 20.8 ug/mL
Beside the measured number, compound 3's estimate is 1.4-fold (0.16 log units) above it; the range from low to high includes it.
By their numbers in this assay, from the lowest: compounds 1 and 2 (each within the scatter of the next); then compound 3.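

In this assay, among the compounds shown here, placing 1-(pyridin-4-yl)ethyl where 4-nitrophenyl stood on the amine nitrogen in a ring gives a 12-fold higher number from compound 2 to compound 3 (1.06 log units; beyond the scatter) and marks the first step that can be read on its own. With the rest of the molecule unchanged, it shows that the group at this one position can move the read-out well beyond the usual scatter of repeated measurements. No measurement at hand bears on the reason for this rise.

This single step changes several things at once: an aromatic ring of carbon only gives way to one with a hetero atom, the nitro group leaves, and the aromatic ring of the entering group is attached to the ring nitrogen through a one-carbon branch bearing a methyl group, so the step cannot assign the rise to any one of these features. Still open, going by these compounds, is how the number would respond to a pyridin-4-yl group placed directly on that nitrogen, to a plain phenyl ring, or to a 1-phenylethyl group, any of which would help to separate these features.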